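The source may hold more compounds than are shown below. What is called first, only, known or untested is meant among the compounds shown, and "the series" means these compounds.

Measured so far:
compound 1, `O=C(O)COc1ccc(NC(=O)COc2ccccc2)cc1F`, 29.8%
compound 2, `Cc1ccc(OCC(=O)Nc2ccc(OCC(=O)O)c(F)c2)cc1`, 31.2%

Both values come from a functional assay on CHO cells for agonist activity at Free fatty acid receptor 1 (Homo sapiens), read by FLIPR, tested at 100 nM; on this read-out lower numbers stand for a weaker effect and higher numbers for a stronger effect at the one concentration tested. Compound 2 stands at the higher of the two numbers, but the step of a number 1.4 percentage points higher from compound 1 to compound 2 (within the scatter) lies within the scatter, so the two compounds cannot be ranked on this evidence. Compound 3 is `CCc1ccc(OCC(=O)Nc2ccc(OCC(=O)O)c(F)c2)cc1`, not yet measured. It differs from compound 2 by methyl in place of hydrogen on a saturated chain carbon bound to an aromatic carbon. For the measured compounds named here, the only measured step that bears on this change is the one from compound 1 to compound 2, where methyl replaced hydrogen on an aromatic carbon and gave a number 1.4 percentage points higher from compound 1 to compound 2 (within the scatter); the present change, cut one bond further out, reads methyl to ethyl on the same ring. One step within the scatter is thin ground, but nothing in it points to a shift in either direction. The expectation for compound 3 in this assay is therefore no step beyond the scatter, a number 0.8 percentage points higher from compound 2 to compound 3 (within the scatter). Compound 3 is accordingly estimated at 32%, with a range from 20% to 44%.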

Compound 3, a percentage reported as activity, at one concentration (the size of the read-out at that concentration, not a potency): 14.6%
Estimate against measurement, compound 3: 17.4 percentage points above; measured number below the stated range.
By their numbers in this assay, from the lowest: compound 3; then compounds 1 and 2 (each within the scatter of the next).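

In this assay, extending the methyl on the ring to an ethyl gives a clear loss (a number 16.6 percentage points lower from compound 2 to compound 3 (beyond the scatter)), so the effect at this position depends on the added saturated carbon, which the methyl-for-hydrogen step on the aromatic carbon could not show. Measured against the unsubstituted ring, the ethyl group gives a step of similar size (a number 15.2 percentage points lower from compound 1 to compound 3 (beyond the scatter)), so the loss belongs to ethyl and not to substitution at this ring position as such. No measurement on hand accounts for this loss.

From the compounds shown here alone, it remains open whether a propyl chain would lower the number further, or whether a branched isopropyl, a methoxy group or a chlorine atom would behave like methyl or like ethyl. With a single concentration, the read-out shows only a stronger or weaker effect at that concentration and leaves open how these differences would look at any other concentration.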